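The compounds below may be only part of what the source reports. "The series", "measured", "known", "first", "only" and "open" are said of these compounds alone.

Compound 1 `COc1ccc(N2COc3ccc(C(=O)/C=C/c4ccccc4Cl)cc3C2)cc1`: 63.4%
Compound 2 `COc1ccc(N2COc3ccc(C(=O)/C=C/c4ccccc4O)cc3C2)cc1`: 55.7%
Compound 3 `Cc1ccc(N2COc3ccc(C(=O)/C=C/c4ccccc4Cl)cc3C2)cc1`: 60.4%

In a functional assay on the whole organism (strain Wistar) for inhibition, with Rattus norvegicus as the target, read by paw edema, with a stated time of 3 h, at a dose of 20 mg/kg by the oral route (a lower number here means less inhibition, a higher number more inhibition at the dose given (going by the name of the read-out)), compound 3 sits between the other two on the numbers shown, with compound 1 a number 3 percentage points lower from compound 1 to compound 3 (within the scatter) and compound 2 on the other side, every gap within the scatter. Compound 4 `Cc1ccc(N2COc3ccc(C(=O)/C=C/c4ccccc4O)cc3C2)cc1` differs from compound 3 by hydroxy in place of chloro on an aromatic carbon. Among the measured compounds shown here, the one measured step that matches this change, on the methoxy-bearing core, is a number 7.7 percentage points lower from compound 1 to compound 2 (within the scatter), which stayed within the scatter. For the measured compounds named here, no other step bears on it. A step of similar size and direction, still within the scatter, is therefore expected here, a number 7.4 percentage points lower from compound 3 to compound 4 (within the scatter). Compound 4 is thus estimated at 53% in this assay, with a range from 42% to 64%.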

Compound 4, a percentage reported as inhibition, in the whole organism at one dose (the size of the read-out at that dose, not a potency): 51%
Beside the measured number, compound 4's estimate is 2 percentage points above it; the measured number falls inside the stated range.
By their numbers in this assay, from the lowest: compounds 4, 2, 3 and 1 (each within the scatter of the next, the first and the last beyond it).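

In this assay, replacing chloro with hydroxy on this aromatic carbon now has a reading on a second core, a number 9.4 percentage points lower from compound 3 to compound 4 (within the scatter), and the two readings agree: the same change on two cores in this assay, a number 7.7 percentage points lower (within the scatter) from compound 1 to compound 2 and a number 9.4 percentage points lower (within the scatter) from compound 3 to compound 4, 1.7 percentage points apart, within the scatter of two such steps Methyl in place of methoxy also gains a second reading, a number 4.7 percentage points lower from compound 2 to compound 4 (within the scatter), which agrees with the first: the same change on two cores in this assay, a number 3 percentage points lower (within the scatter) from compound 1 to compound 3 and a number 4.7 percentage points lower (within the scatter) from compound 2 to compound 4, 1.7 percentage points apart, within the scatter of two such steps Each of these steps stays within the scatter, so neither change is shown to alter the inhibition on its own.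

From the compounds shown here alone, it remains open whether an amine or a carboxylic acid at this position would give a step beyond the scatter.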